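Fluoro to methoxy: working notes on compound 4

The source may hold more compounds than are shown below. What is called first, only, known or untested is meant among the compounds shown, and "the series" means these compounds.

compound 1 `CC1(/C=C/c2ccc(F)cc2)C=CC(=O)O1`: 60800 nM
compound 2 `COc1cc(OC)c(OC)cc1/C=C/C1(C)C=CC(=O)O1`: 160000 nM
compound 3 `CC1(/C=C/c2ccccc2O)C=CC(=O)O1`: 70900 nM

Within the data shown here, all three values come from a functional assay on U-251 cells (Homo sapiens) for inhibition, read by sulforhodamine B assay, with a stated time of 48 h (on this read-out lower numbers stand for stronger inhibition of growth and higher numbers for weaker inhibition of growth), and are the only numbers available for this series. Compound 1 sits at the low end together with compound 3, the two lying within the scatter of each other, while compound 2 lies above compound 1 beyond the scatter. The next compound to be read is compound 4 `COc1ccc(/C=C/C2(C)C=CC(=O)O2)cc1`, which differs from compound 1 by methoxy in place of fluoro on an aromatic carbon. Among the measured compounds shown here, no pair of measured compounds differs in one place only, so the size of this change in this assay cannot be read directly. For the measured compounds named here, compound 2, which also carries methoxy groups, gives 160000 nM and is the only guide, a weak one. The estimated 1.4-fold higher number from compound 1 to compound 4 (0.15 log units; within the scatter) is a small move toward higher numbers, not expected to clear the scatter. Compound 4 is estimated at 85000 nM, with an expected range from 50000 nM to 150000 nM for the coming measurement.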

Compound 4, concentration for total growth inhibition: 127000 nM
For compound 4 the middle estimate is 1.5-fold (0.17 log units) below the measured one; the measured number falls inside the stated range.
By their numbers in this assay, from the lowest: compounds 1, 3, 4 and 2 (each within the scatter of the next, the first and the last beyond it).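

In this assay the series gains its first comparison of compounds that differ in one place: on this aromatic carbon, para to a group of 9 heavy atoms, methoxy in place of fluoro gives a 2.1-fold higher number from compound 1 to compound 4 (0.32 log units; beyond the scatter) and this modest step lies beyond the scatter. The number at this position therefore responds to the change, with fluoro carrying the lower number of the two groups, although this rests on a single pair. Nothing at hand accounts for the step.

As far as these compounds go, whether a hydroxy group, an amine, a carboxylic acid or a longer chain on this same carbon would move the number further in either direction remains open. Also open, from the compounds shown here alone, is whether methoxy in place of fluoro would give a step of similar size on another aromatic carbon.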